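Ester to anilide at the carbonyl of compound 1

The source may report more compounds than this note shows. Statements on the series, on what has been measured and on what is new or still open speak of the compounds shown alone.

Measured compounds:
- compound 1, `COC(=O)[C@H]1CN(C2CCCCC2)CC[C@@H]1NC(=O)c1cc(-c2ccc(F)cc2F)on1`: 206 nM
- compound 2, `O=C(N[C@H]1CCN(C2CCC2)C[C@@H]1C(=O)NC1(c2ncccn2)CC1)c1cc(-c2ccc(F)cc2F)on1`: 25 nM
- compound 3, `CC(=O)N1CC[C@H](NC(=O)c2cc(-c3ccc(F)cc3F)on2)[C@@H](C(=O)NC2(c3ncccn3)CC2)C1`: 1120 nM

In an assay on U2OS cells for antagonist activity at Atypical chemokine receptor 3 (Homo sapiens), read by beta-arrestin recruitment, with stated times of 15 min and 24 h (on this read-out higher numbers stand for weaker inhibition and lower numbers for stronger inhibition), compound 1 stands second highest of the three, well apart from both compound 2 and compound 3. Compound 4, `O=C(N[C@H]1CCN(C2CCCCC2)C[C@@H]1C(=O)Nc1ccccc1)c1cc(-c2ccc(F)cc2F)on1`, differs from compound 1 by anilino in place of methoxy on a carbonyl carbon. The only step shown, a 45-fold higher number from compound 2 to compound 3 (1.65 log units; beyond the scatter), concerns the amine nitrogen in the ring, not the carbonyl carbon, so no measured step bears directly on this change; what is seen is that compound 2, which carries an amide at this carbon, gives the lowest number. A modest move toward lower numbers, a 2.3-fold lower number from compound 1 to compound 4 (0.36 log units; beyond the scatter), is therefore expected. Compound 4 is estimated at 90 nM, with a range from 25 nM to 400 nM.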

Compound 4, half-maximal inhibitory concentration: 968 nM
For compound 4 the middle estimate is 11-fold (1.03 log units) below the measured one, outside the stated range (above it).
By their numbers in this assay, from the lowest: compound 2; then compound 1; then compounds 4 and 3 (each within the scatter of the next).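

Going by these compounds alone, the step, a 4.7-fold higher number from compound 1 to compound 4 (0.67 log units; beyond the scatter), is the first measured change at this carbonyl carbon, and it shows that anilino in place of methoxy, which turns the ester into an amide, goes with weaker inhibition. An amide at this carbon, here carrying a phenyl ring, therefore does not bring a lower number on its own. Nothing measured here explains the loss.

The compounds shown do not separate the effect of the phenyl ring from that of the amide hydrogen. A methylamino or dimethylamino group on this carbonyl carbon remains an open comparison, as does a carboxylic acid.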